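The compounds below may be only part of what the source reports. "The series", "measured", "known", "first", "only" and "open" are said of these compounds alone.

In a functional assay on KG-1 cells (Homo sapiens) for cytotoxicity, read by luminescence and CellTiter-Glo, with a stated time of 3 days (a higher number here means a weaker inhibitor, a lower number a stronger inhibitor), compound 1 (`COc1ccc(O)c(C(=O)Nc2ccc(C#N)cc2)c1`) gives > 10000 nM, which is a limit of the assay and not a number. Compound 1 therefore stands at the limit of > 10000 nM in this assay, at which 1 of the 3 values shown sits. Compound 2 (`N#Cc1ccc(NC(=O)c2ccc(Br)cc2O)c(Cl)c1`) gives 790 nM and compound 3 (`O=C(Nc1ccc(C(F)(F)F)cc1)c1cc(Cl)c(-c2ccccc2)cc1O`) gives 770 nM, two values within the usual scatter of each other.

Compound 4 (`N#Cc1ccc(NC(=O)c2cc(Cl)ccc2O)cc1`) has not yet been measured. It keeps the core of compound 1 and alters a single place: chloro in place of methoxy on an aromatic carbon. This puts chloro in place of methoxy on an aromatic carbon, para to a hydroxy group.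

Within the data shown here, no step between measured compounds is available to size this change. The expectation therefore rests on the numbers alone: compound 2 at 790 nM and compound 3 at 770 nM both return a real value, and neither carries a methoxy group. In this assay a step toward stronger inhibition, beyond the scatter, is expected, and it is estimated as an at least 5.0-fold lower number from compound 1 to compound 4 (0.69 log units; beyond the scatter). Its true size remains uncertain, since the starting point is only a limit. For compound 4 the estimated value is 2000 nM, with an expected range from 500 nM to 9000 nM.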

Compound 4, half-maximal inhibitory concentration: 1860 nM
For compound 4 the middle estimate is 1.1-fold (0.03 log units) above the measured one; low and high end bracket the measured number.
By their numbers in this assay, from the lowest: compounds 3 and 2 (each within the scatter of the next); then compound 4. At a limit, above all of these: compound 1.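

Chloro in place of methoxy on an aromatic carbon, para to a hydroxy group, gives an at least 5.3-fold lower number from compound 1 to compound 4 (0.73 log units; beyond the scatter) in this assay, and this is the only change among the compounds shown that can be read at a single place. Compounds 2 and 3 had already returned real values, but they differ from compound 1 in more than one place, whereas compound 4 shows that this one exchange on the core of compound 1 is enough to bring a real value. The step has a lower bound and no exact size because compound 1 gives a limit of the assay and not a number: the limit of > 10000 nM in this assay, at which 1 of the 4 values shown sits.

The compounds shown leave open how other groups at this place, such as fluoro, methyl or an amine, would compare with chloro, so it remains unknown whether the step follows from the arrival of chloro or from the departure of methoxy. Compounds 2 and 3 also differ from compound 4 in more than one place, so the contribution of each of their other changes remains unsized.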